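The source may hold more compounds than are shown below. What is called first, only, known or untested is meant among the compounds shown, and "the series" means these compounds.

Measured compounds:
compound 1 `O=C(O)c1cc(=O)c2ccc(OCC(O)COc3ccccc3)cc2o1`: 7 ug/mL
compound 2 `CC(=O)c1ccc(OCC(O)COc2ccc3c(=O)cc(C(=O)O)oc3c2)cc1O`: 28 ug/mL
compound 3 `CCCc1ccccc1OCC(O)COc1ccc2c(=O)cc(C(=O)O)oc2c1`: 2 ug/mL

All three share one core and differ only in the group hung on the oxygen of the saturated carbon. In a functional assay on ileum (Cavia porcellus) for antagonist activity, with a stated time of 30 s (on this read-out lower numbers stand for stronger inhibition and higher numbers for weaker inhibition), compound 3 gives the lowest number of the three, set apart by a 3.5-fold lower number from compound 1 to compound 3 (0.54 log units; beyond the scatter) and by a 14-fold lower number from compound 2 to compound 3 (1.15 log units; beyond the scatter), both beyond the scatter.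

Compound 4 `C=CCc1ccccc1OCC(O)COc1ccc2c(=O)cc(C(=O)O)oc2c1` differs from compound 3 by vinyl in place of ethyl on a saturated chain carbon bound to an aromatic carbon. Going by the values given here, the only measured step touching this part of the molecule is a 3.5-fold lower number from compound 1 to compound 3 (0.54 log units; beyond the scatter), a modest gain from adding the whole propyl; no measured step trades one small piece of that chain for another. A step within the scatter is therefore expected in this assay, with no clear direction. Compound 4 is expected to give about 2.5 ug/mL, between 1 ug/mL and 6 ug/mL. That corresponds to an expected step of a 1.3-fold higher number from compound 3 to compound 4 (0.10 log units; within the scatter).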

Compound 4, half-maximal inhibitory concentration: 1.8 ug/mL
The estimate for compound 4 lay 1.4-fold (0.14 log units) above the measured number; the range from low to high includes it.
By their numbers in this assay, from the lowest: compounds 4 and 3 (each within the scatter of the next); then compound 1; then compound 2.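

In this assay, vinyl in place of ethyl adds a double bond to the chain on the saturated chain carbon bound to an aromatic carbon, yet the two numbers cannot be told apart (a 1.1-fold lower number from compound 3 to compound 4 (0.05 log units; within the scatter)). Allyl thus keeps the modest gain seen with propyl over the plain phenyl of compound 1 (a 3.9-fold lower number from compound 1 to compound 4 (0.59 log units; beyond the scatter)), and the large gap from the 4-acetyl-3-hydroxyphenyl group remains (a 16-fold lower number from compound 2 to compound 4 (1.19 log units; beyond the scatter)). No supporting measurement bears on this result. On these data alone, how a longer chain such as butyl, or an amine at the chain's end, would read in this assay remains open.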